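The compounds below may be only part of what the source reports. "The series", "measured", "known", "first", "only" and "open" are said of these compounds alone.

In a functional assay on A-375 cells (Homo sapiens) for antiproliferative activity; a lower number here means a stronger inhibitor, a higher number a weaker inhibitor:
- compound 1 `O=C(Nc1ccc(-c2cscn2)cc1)C1CCCN(Cc2ccccc2F)C1`: 4000 nM
- compound 2 `O=C(Nc1ccc(-c2cscn2)cc1)C1CCCN(Cc2ccc(F)cc2)C1`: 2250 nM
- compound 3 `O=C(Nc1ccc(-c2cscn2)cc1)C1CCCN(Cc2cc(F)c(F)c(F)c2)C1`: 400 nM

Compound 3 has the lowest number of the three. Compound 4 `O=C(Nc1ccc(-c2cscn2)cc1)C1CCCN(Cc2ccc(Cl)c(Cl)c2)C1` differs from it as follows: 3,4-dichlorophenyl in place of 3,4,5-trifluorophenyl on a saturated chain carbon bound to an amine nitrogen in a ring. This places 3,4-dichlorophenyl in place of 3,4,5-trifluorophenyl on a saturated chain carbon bound to an amine nitrogen in a ring.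

All measured steps fall at this same place. a 1.8-fold lower number from compound 1 to compound 2 (0.25 log units; within the scatter) stays within the scatter, while a 10-fold lower number from compound 1 to compound 3 (1.00 log units; beyond the scatter) and a 5.6-fold lower number from compound 2 to compound 3 (0.75 log units; beyond the scatter) go beyond it. Going by the values given here, no measured compound carries chlorine, so these steps show only that this place can move the number in this assay.

No clear direction is expected, and the expected step, a 1.3-fold higher number from compound 3 to compound 4 (0.10 log units; within the scatter), is not expected to exceed the scatter. For compound 4 the estimated value is 500 nM, with an expected range of 150 nM to 1600 nM.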

Compound 4, half-maximal inhibitory concentration: 1730 nM
Compound 4: middle estimate off by 3.5-fold (0.54 log units), on the low side; measured number outside the range, above it.
By their numbers in this assay, from the lowest: compound 3; then compounds 4, 2 and 1 (each within the scatter of the next, the first and the last beyond it).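

In this assay, 3,4-dichlorophenyl does not carry over the result of 3,4,5-trifluorophenyl at this place, with a 4.3-fold higher number from compound 3 to compound 4 (0.64 log units; beyond the scatter). Against the singly fluorinated groups the picture splits: a 1.3-fold lower number from compound 2 to compound 4 (0.11 log units; within the scatter) shows no real difference, while a 2.3-fold lower number from compound 1 to compound 4 (0.36 log units; beyond the scatter) is a modest gain. Nothing available explains the difference between these halogenated groups.

Still open, from the compounds shown here alone, is whether the halogen or the number of halogens matters more at this place. 3,4-Difluorophenyl and 3,4,5-trichlorophenyl would separate the two, and a methoxy-bearing phenyl would test whether halogen is needed at all.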